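This account rests on a few compounds, and the source may have more. Where it says the series, first, only, none or still open, it means among the compounds named here.

Measured in an ADME assay on MT4 cells (Homo sapiens) for cytotoxicity, read by MTT assay, with a stated time of 5 days (on this read-out lower numbers stand for higher toxicity in this test and higher numbers for lower toxicity in this test), so far are three compounds. Compound 1 `Cc1cc(C)cc(S(=O)(=O)c2c(C(=O)N[C@H]3CCN(Cc4n[nH]c(=O)n4C)C3)[nH]c3ccc(Cl)cc23)c1` gives 21500 nM. Compound 2 `Cc1cc(C)cc(S(=O)(=O)c2c(C(=O)N[C@H]3CCN(S(C)(=O)=O)C3)[nH]c3ccc(Cl)cc23)c1` gives 29900 nM. Compound 3 `Cc1cc(C)cc(S(=O)(=O)c2c(C(=O)NC3CN(Cc4ccccc4C#N)C3)[nH]c3ccc(Cl)cc23)c1` reaches only a limit, > 234000 nM, which is the limit of > 234000 nM in this assay, at which 1 of the 3 values shown sits.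

Compound 2 therefore holds the highest of the two numbers, with compound 1 nearest: a 1.4-fold higher number from compound 1 to compound 2 (0.14 log units; within the scatter). Compound 4 `Cc1cc(C)cc(S(=O)(=O)c2c(C(=O)NS(=O)(=O)c3ccc(F)cc3F)[nH]c3ccc(Cl)cc23)c1` differs from compound 2 by (2,4-difluorophenyl)sulfonyl in place of 1-(methylsulfonyl)pyrrolidin-3-yl on an amide-type nitrogen. Among the measured compounds shown here, the one measured step, from compound 1 to compound 2, swaps a group on an amine nitrogen in a ring and stayed within the scatter; no step touches the amide-type nitrogen, so none bears directly on this change. Compound 4 is expected to land near compound 2, a step of a 1.5-fold higher number from compound 2 to compound 4 (0.18 log units; within the scatter) in this assay. The estimate for compound 4 is 45000 nM, between 15000 nM and 150000 nM.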

Compound 4, half-maximal cytotoxic concentration: 121000 nM
Beside the measured number, compound 4's estimate is 2.7-fold (0.43 log units) below it, and the stated range covers the measured number.
By their numbers in this assay, from the lowest: compounds 1 and 2 (each within the scatter of the next); then compound 4. At a limit, above all of these: compound 3.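

In this assay, the amide-type nitrogen proves to be a place where a change moves the number beyond the scatter: (2,4-difluorophenyl)sulfonyl in place of 1-(methylsulfonyl)pyrrolidin-3-yl gives a 4.0-fold higher number from compound 2 to compound 4 (0.61 log units; beyond the scatter), while the earlier step, on an amine nitrogen in a ring, stayed within it. This single pair links the entering group to lower toxicity in this test, but it sets no general pattern. Nothing given here accounts for the size of this step. On these data alone, it remains open whether the step depends on the sulfonyl group or on the two fluorine atoms, and how a methylsulfonyl or an unsubstituted phenylsulfonyl group on this nitrogen would read.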